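The source may hold more compounds than are shown below. What is called first, only, known or untested is meant among the compounds shown, and "the series" means these compounds.

Within the data shown here, compound 2 `Fc1ccc(OCC2=NCCO2)cc1` stands highest of the two numbers so far in a toxicity assay on the whole organism with Rattus norvegicus as the target, at a dose of 100 mg/kg by the oral route (on this read-out higher numbers stand for a stronger effect at the one dose given and lower numbers for a weaker effect), where compound 2 gives 50%. Its nearest neighbour is compound 1 `COc1ccc(OCC2=NCCO2)cc1`, which in this assay gives 5%, and the step of a number 45 percentage points higher from compound 1 to compound 2 (beyond the scatter) lies beyond the scatter. Compound 3 `O=[N+]([O-])c1ccc(OCC2=NCCO2)cc1` differs from compound 2 by nitro in place of fluoro on an aromatic carbon. Among the measured compounds shown here, the only measured step that bears on this position is a number 45 percentage points higher from compound 1 to compound 2 (beyond the scatter), a large change on exchanging one group for another on the same aromatic carbon. Nitro in place of fluoro on that carbon has no measured precedent here, so the direction of the coming step is open; a change of similar size in either direction is possible, and the estimate leans toward a moderate fall. Compound 3 is therefore expected to give 30%, in a range from 5% to 60%, which corresponds to an expected step of a number 20 percentage points lower from compound 2 to compound 3 (beyond the scatter).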

Compound 3, a percentage reported as activity, at one dose (the size of the read-out at that dose, not a potency): 10%
Compound 3: the middle estimate sits 20 percentage points above what was measured; the measured number falls inside the stated range.
By their numbers in this assay, from the lowest: compounds 1 and 3 (each within the scatter of the next); then compound 2.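

In this assay the same aromatic carbon now gives a second large step, a number 40 percentage points lower from compound 2 to compound 3 (beyond the scatter), so the exchange of fluoro for another group has moved the read-out by a wide margin in both comparisons. The two groups that replace fluoro do not separate from each other, with a number 5 percentage points higher from compound 1 to compound 3 (within the scatter), which leaves compound 2 alone above compound 1 and compound 3. Nothing measured here accounts for this difference between the groups.

As far as these compounds go, whether the higher read-out is particular to fluoro or extends to chloro or bromo remains open, as does the place of an amine or a carboxylic acid on this carbon. From the compounds shown here alone, all three compounds vary at this one carbon, so how the read-out responds to changes elsewhere on the shared core also remains open.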